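Open chain to cyclopentyl: estimating compound 4

This account rests on a few compounds, and the source may have more. Where it says the series, first, only, none or still open, it means among the compounds named here.

Measured in an ADME assay on CEM-SS cells (Homo sapiens) for cytotoxicity, read by XTT assay, with a stated time of 6 days; a lower number here means that less compound is tolerated, a higher number that more compound is tolerated:
- compound 1 `CCCC(=O)OCSc1ccccc1C(=O)NCCC(N)=O`: > 100 uM (a limit)
- compound 2 `CCCC(=O)OCSc1ccccc1C(=O)NCCCCCC(N)=O`: 16.3 uM
- compound 3 `CCCC(=O)OCSc1ccccc1C(=O)N[C@H]1CCC[C@@H]1C(N)=O`: 31.2 uM; 43.3 uM (2 entries)

Within the data shown here, compound 2 gives 16.3 uM, the only single number among the three measured compounds. Compound 1 gives > 100 uM, which is a limit of the assay and not a number. Compound 3 has more than one entry, as the several entries of compound 3 in this assay, 31.2 uM; 43.3 uM (2 entries) shows.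

The next compound is compound 4 `CCCC(=O)OCSc1ccccc1C(=O)N[C@@H]1CCC[C@@H]1C(N)=O`. Its change from compound 2 is 2-carbamoylcyclopentyl in place of 5-carbamoylpentyl on an amide-type nitrogen.

Among the measured compounds shown here, the one measured step is an at least 6.1-fold lower number from compound 1 to compound 2 (0.78 log units; beyond the scatter). It concerns chain length and has only a lower bound on its size, so it bears on compound 4 only loosely. The closer guide is compound 3, which also carries 2-carbamoylcyclopentyl but differs from compound 4 in its defined stereocentres. Compound 3 gives 31.2 uM; 43.3 uM (2 entries) in this assay. For the measured compounds named here, no measurement yet shows what that stereochemical difference does, so the range stays wide.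

A modest move toward more compound tolerated is expected, as the estimated 2.0-fold higher number from compound 2 to compound 4 (0.31 log units; beyond the scatter). For compound 4 the expected value is 33 uM, with an estimated range of 14 uM to 85 uM.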

Compound 4, half-maximal toxic concentration: 90 uM
Compound 4: the middle estimate sits 2.7-fold (0.44 log units) below what was measured, and the stated range ends below it.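

In this assay, 2-carbamoylcyclopentyl in place of 5-carbamoylpentyl on the amide-type nitrogen gives a 5.5-fold higher number from compound 2 to compound 4 (0.74 log units; beyond the scatter), so at this position, the ring form of the substituent gives a modest move toward more compound tolerated than the open chain, although the two groups have the same count of heavy atoms. The ring alone does not set the number, as compound 3 carries the same group and gives 31.2 uM; 43.3 uM (2 entries), while compound 4 gives 90 uM, and the only structural difference within this pair is stated here: the fact that compounds 3 and 4 differ only in the configuration as drawn. Compound 1 gives > 100 uM, a limit of the assay and not a number. The step that this limit allows is an at least 1.1-fold lower number from compound 1 to compound 4 (0.04 log units; that floor lies within the scatter), so it gives a floor only and not a size.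

The two remaining configurations of 2-carbamoylcyclopentyl are open, so the compounds shown do not tell whether the value of compound 4 is the top of a range or a midpoint among the stereoisomers. Also open, on these data alone, is whether the same change holds for a cyclohexyl ring in place of the cyclopentyl ring, or for a carboxylic acid in place of the terminal carbamoyl group.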